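From pyridin-2-yl to pyridin-3-yl in compound 3

The source may hold more compounds than are shown below. What is called first, only, known or untested is meant among the compounds shown, and "the series" means these compounds.

- compound 1 `O=c1c2cncn2nc(SCc2cccc(F)c2)n1-c1ccccc1` gives 47000 nM
- compound 2 `CC(Sc1nc2nn(C3COC3)cc2c(=O)n1-c1ccccc1)c1ccccn1` gives 60000 nM

Both numbers come from a physicochemical assay for solubility, using the shake flask method, in phosphate buffer, with a stated time of 24 h, at pH 7.4 (on this read-out higher numbers stand for higher solubility and lower numbers for lower solubility), and they lie within the usual scatter of repeated measurements, so neither compound can be ranked above the other. Compound 2 therefore stands alongside compound 1 on the numbers available. These two compounds differ in more than one place, so no measured single change is available as a guide.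

The next compound, compound 3 `CC(Sc1nc2nn(C3COC3)cc2c(=O)n1-c1ccccc1)c1cccnc1`, has the same atoms as compound 2, joined differently. It carries pyridin-3-yl in place of pyridin-2-yl on a saturated chain carbon bound to a saturated chain carbon and a sulfur.

For the measured compounds named here, with no measured step to lean on, the expectation starts from compound 2 at 60000 nM and assumes no shift in either direction beyond the scatter in this assay. The expected size is no change at the digits printed from compound 2 to compound 3 (within the scatter) and it is estimated to stay within the scatter. Compound 3 is expected at 60000 nM in a range from 25000 nM to 140000 nM on this estimate.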

Compound 3, solubility: 189000 nM
For compound 3 the middle estimate is 3.2-fold (0.50 log units) below the measured one; the whole stated range lies below it.
By their numbers in this assay, from the lowest: compounds 1 and 2 (each within the scatter of the next); then compound 3.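

For the compounds shown here, compound 3 provides the first measured single change in this set, and it shows that this position is not indifferent to how the pyridine is attached: in this assay, replacing pyridin-2-yl with pyridin-3-yl on a saturated chain carbon bound to a saturated chain carbon and a sulfur gives a 3.2-fold higher number from compound 2 to compound 3 (0.50 log units; beyond the scatter). The two groups have the same heavy atoms, the same ring size and the same counts of hydrogen-bond donors and acceptors, and neither carries a net charge, so these counts cannot separate them even though the read-out does. No measurement here explains why the number moves with this change.

The compounds shown leave open how pyridin-4-yl would read at the same place, and whether an amine or a carboxylic acid on the pyridine ring would move the number further in either direction. They also leave open whether the same change from pyridin-2-yl to pyridin-3-yl would give a similar step on another core, such as the core of compound 1.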